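The source may report more compounds than this note shows. Statements on the series, on what has been measured and on what is new or still open speak of the compounds shown alone.

Series notes. Within the data shown here, in a functional assay on MDA-MB-231 cells (Homo sapiens) for cytotoxicity, read by MTT assay, with a stated time of 24 h (a lower number here means a stronger inhibitor, a higher number a weaker inhibitor), compound 2 (`CC(=O)Nc1ccc(Oc2cccc3c(NC(=O)Nc4ccccc4)cccc23)cc1`) gives 1410 nM and compound 1 (`CC(=O)Nc1ccc(Oc2cccc3c(NC(=O)Nc4cccc(C(F)(F)F)c4)cccc23)cc1`) gives 1410 nM, so compound 2 stands level with the only other measured compound. Next in line is compound 3 (`CC(=O)Nc1ccc(Oc2cccc3c(NC(=O)Nc4ccc(Cl)c(C(F)(F)F)c4)cccc23)cc1`), which carries 4-chloro-3-(trifluoromethyl)phenyl in place of phenyl on an amide-type nitrogen. Among the measured compounds shown here, one measured step bears on this change: no change at the digits printed from compound 1 to compound 2 (within the scatter), with hydrogen in place of trifluoromethyl on an aromatic carbon. That step concerns the trifluoromethyl part of the incoming group only, and it stayed within the scatter. For the measured compounds named here, the chlorine has no measured step of its own, and two compounds give no basis for a trend. No step beyond the scatter is therefore expected in this assay, and the data offer no firm direction. The expected step is a 1.1-fold lower number from compound 2 to compound 3 (0.04 log units; within the scatter), with a wide margin for the untested chlorine. For compound 3 the estimated value is 1300 nM, with an expected range from 550 nM to 3000 nM.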

Compound 3, half-maximal inhibitory concentration: 1410 nM
Compound 3: the middle estimate sits 1.1-fold (0.04 log units) below what was measured; low and high end bracket the measured number.
By their numbers in this assay, from the lowest: compounds 1, 2 and 3 (each within the scatter of the next).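

In this assay, 4-chloro-3-(trifluoromethyl)phenyl in place of phenyl on an amide-type nitrogen gives no change at the digits printed from compound 2 to compound 3 (within the scatter), so a group of 11 heavy atoms and one of 6 at this place read the same, and the two substituents together leave the number as level as trifluoromethyl did alone. Among these compounds, the chloro, which had no measured step of its own before, now has one: chloro in place of hydrogen on an aromatic carbon gives no change at the digits printed from compound 1 to compound 3 (within the scatter), so within these three compounds neither substituent on this ring has yet produced a step beyond the scatter. No supporting measurement bears on why the three compounds stand level.

On these data alone, what remains open is whether this ring responds at all to a different kind of substituent, such as an amine or a carboxylic acid, or to a longer chain in place of the ring. The acetamide end of the shared core is also identical in all three compounds, so these steps say nothing about replacing its acetyl group with, for example, a methanesulfonyl group.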